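The compounds below may be only part of what the source reports. "The series", "measured", "known", "first", "only" and "open" are said of these compounds alone.

Of the compounds shown here, two of a shared core have been measured. Compound 1 `COC(=O)/C=C/c1cccc(N(Cc2ccc(/C=C/c3ccccc3F)cc2)C(=O)C2CCCCC2)c1` gives 64 nM in an assay on isolated protein with Bile acid receptor (Homo sapiens) as the target; a higher number here means that more compound is needed for the effect, a lower number that less compound is needed. Within the data shown here, compound 2 `COC(=O)/C=C/c1cccc(N(Cc2ccc(-c3ccc(OC(F)(F)F)cc3)cc2)C(=O)C2CCCCC2)c1` gives 264 nM in this assay, which places it at the higher of the two numbers; the one step known, a 4.1-fold higher number from compound 1 to compound 2 (0.62 log units; beyond the scatter), moved the number by a modest amount. Compound 3 `COC(=O)/C=C/c1cccc(N(Cc2ccc(-c3cccc(OC(F)(F)F)c3)cc2)C(=O)C2CCCCC2)c1` differs from compound 2 only in where a group sits: 3-(trifluoromethoxy)phenyl in place of 4-(trifluoromethoxy)phenyl on an aromatic carbon. No measured step among these compounds bears directly on such a shift of the same group from one position to another, since the single measured step exchanged one group for a different one. With no guide of that kind, the number for compound 3 is expected to stay near that of compound 2, and the step of a 1.1-fold lower number from compound 2 to compound 3 (0.02 log units; within the scatter) is estimated to lie within the usual scatter. Compound 3 is therefore estimated at 250 nM in this assay, with a range from 80 nM to 800 nM.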

Compound 3, half-maximal effective concentration: 420 nM
Compound 3: the middle estimate sits 1.7-fold (0.23 log units) below what was measured; measured number inside the range.
By their numbers in this assay, from the lowest: compound 1; then compounds 2 and 3 (each within the scatter of the next).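

In this assay the exchange of 4-(trifluoromethoxy)phenyl for 3-(trifluoromethoxy)phenyl gives a 1.6-fold higher number from compound 2 to compound 3 (0.20 log units; within the scatter) and so does not separate these two placements of the same group. The 2-(2-fluorophenyl)ethenyl group of compound 1 also stands apart from this second placement, with a 6.6-fold higher number from compound 1 to compound 3 (0.82 log units; beyond the scatter) beyond the scatter, so both trifluoromethoxy compounds give higher numbers than compound 1. Nothing available accounts for these numbers.

The compounds shown leave open how the numbers would respond to a carboxylic acid in place of the methyl ester, or to an amine or a nitrile in place of the trifluoromethoxy group. From the compounds shown here alone, the exchange from compound 1 also changes the ethenyl link and the ring substituent together, and the share of each stays open.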